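The source may report more compounds than this note shows. Statements on the series, on what has been measured and on what is new or still open speak of the compounds shown alone.

Measured so far:
compound 1 `CC(C)(C)OC(=O)N1CCC(O[C@H]2CC[C@H](Oc3ccc(S(C)(=O)=O)nn3)CC2)CC1`, 1160 nM
compound 2 `CC(C)OC(=O)N1CCC(O[C@H]2CC[C@H](Oc3cnc(S(C)(=O)=O)cn3)CC2)CC1`, 119 nM

In a functional assay on isolated protein for agonist activity at Glucose-dependent insulinotropic receptor (Rattus norvegicus), read by HTRF and cAMP accumulation (a lower number here means that less compound is needed, a higher number that more compound is needed for the effect), compound 2 gives 119 nM, the lowest of the two numbers; compound 1 gives 1160 nM, a gap beyond the scatter. Compound 3 `CC(C)c1noc(CN2CCC(O[C@H]3CC[C@H](Oc4cnc(S(C)(=O)=O)cn4)CC3)CC2)n1` differs from compound 2 by (3-isopropyl-1,2,4-oxadiazol-5-yl)methyl in place of isopropoxycarbonyl on an amine nitrogen in a ring. Within the data shown here, no measured pair covers this change, so its size is unknown. A modest rise in this assay is expected, though it may well stay within the scatter, giving an expected step of a 1.8-fold higher number from compound 2 to compound 3 (0.27 log units; within the scatter). Compound 3 is estimated at 220 nM, with a range from 60 nM to 800 nM.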

Compound 3, half-maximal effective concentration: 97.9 nM
Estimate against measurement, compound 3: 2.2-fold (0.35 log units) above, and the stated range covers the measured number.
By their numbers in this assay, from the lowest: compounds 3 and 2 (each within the scatter of the next); then compound 1.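

In this assay the amine nitrogen in a ring takes (3-isopropyl-1,2,4-oxadiazol-5-yl)methyl in place of isopropoxycarbonyl with a 1.2-fold lower number from compound 2 to compound 3 (0.08 log units; within the scatter) as the only shift. This position therefore accepts a group with a five-membered aromatic ring and no carbonyl, with no change beyond the scatter. No data here bear on why the two groups read alike.

As far as these compounds go, whether a benzyl group or an amide on this nitrogen would read the same remains open. So does whether a cyclopropyl or a longer chain could replace the isopropyl on the oxadiazole.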